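A few compounds are considered here, and "the series" means these few. Any claim that something is new, unique, unknown or untested is made for them only; others in the source may bear on it.

Compound 1, `O=C(C(Nc1ccccc1)c1ccc(C(F)(F)F)cc1)N1CCC[C@H]1c1ccccc1Cl`: 41 nM
Compound 2, `O=C(C(Nc1ccccc1F)c1ccc(C(F)(F)F)cc1)N1CCCC1c1ccccc1Cl`: 11 nM
Compound 3, `O=C(C(Nc1cccc(F)c1)c1ccc(C(F)(F)F)cc1)N1CCCC1c1ccccc1Cl`: 138 nM

These three compounds share one core and differ only in the aryl group on the amine nitrogen. In an assay on HEK293 cells for antagonist activity at transient receptor potential M8 protein (Canis lupus familiaris), read by fluorescence and calcium flux, with a stated time of 5 min (on this read-out higher numbers stand for weaker inhibition and lower numbers for stronger inhibition), compound 3 gives 138 nM, the highest number of the three, and its gaps to compound 1 and to compound 2 both lie beyond the scatter, so compound 3 is the weakest inhibitor among those measured.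

Compound 4, `O=C(C(Nc1ccc(F)cc1)c1ccc(C(F)(F)F)cc1)N1CCCC1c1ccccc1Cl`, is compound 3 with the fluorine moved: 4-fluorophenyl in place of 3-fluorophenyl on an amine nitrogen. Among the compounds with values here, no measured pair tests this change directly. Within the data shown here, the only step that bears on the place of the fluorine is a 13-fold higher number from compound 2 to compound 3 (1.10 log units; beyond the scatter), which shows that moving the fluorine around the ring can shift the number a great deal. Compound 1 carries no fluorine on that ring and gives 41 nM in this assay, which sits between compound 2 and compound 3. Among the measured compounds shown here, with no measured 4-fluorophenyl analogue, the direction of the step is uncertain, but a move away from the least favourable position seen so far is expected to lower the number somewhat, with a wide range.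

Compound 4 is therefore estimated at 70 nM in this assay, within 20 nM to 250 nM, which means an expected step of a 2.0-fold lower number from compound 3 to compound 4 (0.29 log units; within the scatter).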

Compound 4, half-maximal inhibitory concentration: 73 nM
Compound 4: the middle estimate sits 1.0-fold (0.02 log units) below what was measured, and the stated range covers the measured number.
By their numbers in this assay, from the lowest: compound 2; then compounds 1, 4 and 3 (each within the scatter of the next, the first and the last beyond it).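

In this assay, the change to the 4-fluorophenyl group on the amine nitrogen comes with a 1.9-fold lower number from compound 3 to compound 4 (0.28 log units; within the scatter), so the 3-fluorophenyl and 4-fluorophenyl compounds cannot be told apart at this position. The 2-fluorophenyl group stands apart from both of them, since the same change made from that group comes with a 6.6-fold higher number from compound 2 to compound 4 (0.82 log units; beyond the scatter), and the large gap first seen with compound 3 is therefore not peculiar to that one isomer. No evidence is given here that would account for this difference among the fluorine placements.

Compound 1 has no fluorine on this ring but differs from compound 2, compound 3 and compound 4 in more than one place, so the shown compounds leave open how each fluorine placement compares with the plain phenyl group on an otherwise identical core. From the compounds shown here alone, it also remains open whether the standing of the 2-fluorophenyl compound is specific to fluorine or would carry over to a chlorine, a methoxy group or a nitrile in its place.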